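Furan swap on the measured chalcone-type pair

The source may hold more compounds than are shown below. What is called first, only, known or untested is meant among the compounds shown, and "the series" means these compounds.

- compound 1 `COc1cc(C(=O)/C=C/c2ccc(Cl)c(Cl)c2)cc(OC)c1OC` gives 44000 nM
- compound 2 `COc1cc(OC)c(OC)cc1/C=C/C(=O)c1cc(OC)c(OC)c(OC)c1` gives 42500 nM

In a functional assay on L1210 cells (Mus musculus) for cytotoxicity, read by MTT assay, with a stated time of 24 h (on this read-out higher numbers stand for weaker inhibition and lower numbers for stronger inhibition), compound 1 stands at 44000 nM and compound 2 at 42500 nM on the same scale. These two values lie within the scatter of each other, so neither ranks ahead.

Compound 3 `COc1cc(C(=O)/C=C/c2ccc(C)o2)cc(OC)c1OC` keeps the core of compound 1 and carries the change 5-methylfuran-2-yl in place of 3,4-dichlorophenyl on a double-bonded chain carbon bound to a double-bonded chain carbon. Among the compounds with values here, no measured step covers this kind of change, so the expectation is weakly founded. A small move toward stronger inhibition in this assay is expected, possibly no larger than the scatter. The expected step is a 1.8-fold lower number from compound 1 to compound 3 (0.25 log units; within the scatter) in size. The estimate for compound 3 is 25000 nM with an expected range from 8000 nM to 70000 nM in this read-out.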

Compound 3, half-maximal inhibitory concentration: 46500 nM
For compound 3 the middle estimate is 1.9-fold (0.27 log units) below the measured one; measured number inside the range.
By their numbers in this assay, from the lowest: compounds 2, 1 and 3 (each within the scatter of the next).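

The step in this assay is a 1.1-fold higher number from compound 1 to compound 3 (0.02 log units; within the scatter), for 5-methylfuran-2-yl in place of 3,4-dichlorophenyl on a double-bonded chain carbon bound to a double-bonded chain carbon. At this place, therefore, a five-membered aromatic ring with 1 hetero atom and a six-membered aromatic ring of carbon only cannot be told apart on the shared core, and the two chlorine atoms are not required for a reading at this level. No measured evidence bears on why these two groups read alike.

On these data alone, whether a group of another kind at this place, such as a phenyl ring carrying a dimethylamino group or a carboxylic acid, would separate from compound 1 beyond the scatter remains open. This single step also leaves open whether the same exchange would read alike on another core.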